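Aryl ketone variation on the chalcone-type quinoline series

This account rests on a few compounds, and the source may have more. Where it says the series, first, only, none or still open, it means among the compounds named here.

Compound 1 `COc1ccc(-c2cc3ccccc3nc2/C=C/C(=O)c2ccc([N+](=O)[O-])cc2)cc1` gives 770 nM in a functional assay on NCI-H1299 cells (Homo sapiens) for antiproliferative activity, read by XTT assay, with a stated time of 72 h; a higher number here means a weaker inhibitor, a lower number a stronger inhibitor. Going by the values given here, compound 2 `COc1ccc(-c2cc3ccccc3nc2/C=C/C(=O)c2cccs2)cc1` gives 720 nM in this assay, and the change a 1.1-fold lower number from compound 1 to compound 2 (0.03 log units; within the scatter) is the only measured step in the set. Compound 2 thus carries the lower of the two numbers, but the two values lie within the scatter of each other, so no order between compound 1 and compound 2 can be read from them.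

Compound 3 `COc1ccc(-c2cc3ccccc3nc2/C=C/C(=O)c2c[nH]c3ccccc23)cc1` is not yet measured. It differs from compound 2 by 1H-indol-3-yl in place of thiophen-2-yl on a carbonyl carbon. Among the compounds with values here, the one measured step also exchanged the aryl group on the carbonyl carbon and produced no shift beyond the scatter, so a further exchange at the same place is expected to behave alike. The step of a 1.1-fold lower number from compound 2 to compound 3 (0.02 log units; within the scatter) from compound 2 to compound 3 is therefore expected to stay within the scatter. Compound 3 is estimated at 680 nM, with a range from 300 nM to 1600 nM.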

Compound 3, half-maximal inhibitory concentration: > 10000 nM
Compound 3: no number, only a limit (the forecaster's own chance of this, stated with the estimate: 3%); middle value at least 14-fold (1.16 log units) from the limit.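

The position on the carbonyl carbon is not indifferent to the group it carries: in this assay, the change to 1H-indol-3-yl gives an at least 13-fold higher number from compound 2 to compound 3 (1.14 log units; beyond the scatter) and an at least 12-fold higher number from compound 1 to compound 3 (1.11 log units; beyond the scatter). The two earlier groups, thiophen-2-yl and 4-nitrophenyl, lie within the scatter of each other, so the tolerance seen there does not extend to every aromatic group at this place. Compound 3 gives > 10000 nM, which is a limit of the assay and not a number, so each step has a floor but no known full size: the limit of > 10000 nM in this assay, at which 1 of the 3 values shown sits.

The compounds shown do not separate the added six-membered aromatic ring of 1H-indol-3-yl from its hydrogen-bond donor as the feature that goes with this step. A benzothiophen-3-yl group, or an indol-3-yl group with a methyl on its ring nitrogen, would bear on that question.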